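A few compounds are considered here, and "the series" means these few. Any claim that something is new, unique, unknown or untested is made for them only; others in the source may bear on it.

Compound 1 `O=C(NC1CCCCC1)Oc1cccc(-c2ccc(F)cc2)c1` gives 65 nM in an assay on cell membranes for binding affinity to Fatty-acid amide hydrolase 1 (Rattus norvegicus); on this read-out higher numbers stand for weaker inhibition and lower numbers for stronger inhibition. Compound 2 `O=C(NC1CCCCC1)Oc1cccc(-c2cccc([N+](=O)[O-])c2)c1` gives 49.6 nM in this assay.

Compound 2 stands at the lowest of the two numbers, with compound 1 close enough to lie within the scatter, so no order between them can be claimed. Compound 3 `O=C(NC1CCCCC1)Oc1cccc(-c2cccc(CO)c2)c1` differs from compound 2 by hydroxymethyl in place of nitro on an aromatic carbon. Going by the values given here, no measured pair shows a change of this kind, so its size is open; the expectation is a modest shift toward a lower number, not far beyond the scatter. Compound 3 is expected to give 30 nM, between 8 nM and 110 nM, an estimated step of a 1.7-fold lower number from compound 2 to compound 3 (0.22 log units; within the scatter).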

Compound 3, half-maximal inhibitory concentration: 8.67 nM
Compound 3: middle estimate off by 3.5-fold (0.54 log units), on the high side; the range from low to high includes it.
By their numbers in this assay, from the lowest: compound 3; then compounds 2 and 1 (each within the scatter of the next).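

Here a change on this aromatic carbon first moves the number in this assay beyond the scatter: hydroxymethyl in place of nitro gives a 5.7-fold lower number from compound 2 to compound 3 (0.76 log units; beyond the scatter). Swapping the whole 4-fluorophenyl for 3-(hydroxymethyl)phenyl gives a 7.5-fold lower number from compound 1 to compound 3 (0.87 log units; beyond the scatter), so compound 3 stands clearly apart from two compounds that could not be separated from each other. Nothing at hand explains this step.

Going by these compounds, whether the drop is specific to hydroxymethyl remains open. An amine, a carboxylic acid or a longer chain such as hydroxyethyl on this same carbon would show how far it extends.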